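The compounds below may be only part of what the source reports. "The series", "measured", "known", "first", "only" and "open" are said of these compounds alone.

Working notes on the series, with values so far in a functional assay on MV4-11 cells (Homo sapiens) for inhibition, read by resazurin assay, with a stated time of 72 h; a higher number here means a weaker inhibitor of growth, a lower number a stronger inhibitor of growth

- compound 1 `COCCSc1nc(C)c(-c2ccnc(Nc3ccc(OC)cc3OC)n2)s1` gives 810 nM
- compound 2 `COc1ccc(Nc2nccc(-c3c[nH]c4ccccc34)n2)c(OC)c1` gives 600 nM
- compound 3 `CCCn1cc(-c2ccnc(Nc3ccc(OC)cc3OC)n2)c2ccccc21` gives 3620 nM

Compound 1 stands within the scatter of compound 2, and compound 3 lies higher than both, beyond the scatter. Compound 4 `COc1ccc(Nc2nccc(-c3sc(N(C)C)nc3C)n2)c(OC)c1` carries dimethylamino in place of (2-methoxyethyl)sulfanyl on an aromatic carbon of compound 1 dimethylamino in place of (2-methoxyethyl)sulfanyl on an aromatic carbon and is otherwise unchanged. Among the compounds with values here, the only measured step is modest, a 6.0-fold higher number from compound 2 to compound 3 (0.78 log units; beyond the scatter) and it lies at a different place, so it bears on this change only loosely. No step beyond the scatter is therefore expected in this assay and no direction is favoured. The expected outcome is a 1.4-fold lower number from compound 1 to compound 4 (0.13 log units; within the scatter) by this estimate. For compound 4 the estimated value is 600 nM with an expected range from 200 nM to 1800 nM for now.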

Compound 4, concentration for 50% growth inhibition: 170 nM
Compound 4: the middle estimate sits 3.5-fold (0.55 log units) above what was measured; measured number outside the range, below it.
By their numbers in this assay, from the lowest: compound 4; then compounds 2 and 1 (each within the scatter of the next); then compound 3.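

In this assay, the group on the aromatic carbon next to the ring nitrogen and next to the ring sulfur affects growth inhibition: dimethylamino in place of (2-methoxyethyl)sulfanyl gives a 4.8-fold lower number from compound 1 to compound 4 (0.68 log units; beyond the scatter). This is the first step shown at this position, and it lies beyond the scatter. Nothing at hand accounts for the step.

Open, from the compounds shown here alone, is whether the change follows the attached nitrogen or the shorter group. Also open, going by these compounds, is how a morpholine or a primary amine at this position would compare with dimethylamino.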